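Fused Heteroaryl Swap on a Sulfonyl Benzylamide Scaffold

This account rests on a few compounds, and the source may have more. Where it says the series, first, only, none or still open, it means among the compounds named here.

Measured compounds:
Compound 2, `O=C(NCc1ccc(S(=O)(=O)c2ccccc2)cc1)c1cc2ccncc2s1`: 14 nM
Compound 1, `O=C(NCc1ccc(S(=O)(=O)c2ccccc2)cc1)c1cc(-c2cccnc2)[nH]n1`: > 10000 nM
Compound 3, `CC(NC(=O)c1cc2cnccc2[nH]1)c1ccc(S(=O)(=O)N2CCCCC2)cc1`: > 10000 nM

For the measured compounds named here, in a functional assay on A2780 cells (Homo sapiens) for inhibition, read by sulforhodamine B assay, with a stated time of 72 h (on this read-out lower numbers stand for stronger inhibition and higher numbers for weaker inhibition), compound 2 gives 14 nM, the only actual number among the three values shown. Compound 1 reaches only a limit of the assay, > 10000 nM. Compound 3 likewise returns a limit, > 10000 nM. Going by the values given here, the set is therefore dominated by the limit of > 10000 nM in this assay, at which 2 of the 3 values shown sit, and compound 2 stands alone as the one compound with a measured potency. Among the compounds with values here, no two measured compounds differ in a single place, so no measured step is available to calibrate the change that follows.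

Compound 4, `O=C(NCc1ccc(S(=O)(=O)c2ccccc2)cc1)c1ccc2nncn2c1`, keeps the benzylamide and the phenylsulfonyl portion of compound 2 and alters the bicyclic amide partner: a group of 9 heavy atoms (6 carbon, 3 nitrogen; one five-membered aromatic ring with 3 hetero atoms, one six-membered aromatic ring with 1 hetero atom) in place of a group of 9 heavy atoms (7 carbon, 1 nitrogen, 1 sulfur; one five-membered aromatic ring with 1 hetero atom, one six-membered aromatic ring with 1 hetero atom), on a carbonyl carbon. Both compounds carry a fused bicyclic aromatic on the carbonyl carbon, which is the feature that the inactive compounds 1 and 3 do not share in the same arrangement, so a complete loss is not the first expectation. Within the data shown here, still, with no measured step to lean on, the change from compound 2 to compound 4 is expected to cost potency, an 18-fold higher number from compound 2 to compound 4 (1.25 log units; beyond the scatter), with wide uncertainty. Compound 4 is therefore estimated at 250 nM, within a range of 25 nM to 3000 nM.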

Compound 4, half-maximal inhibitory concentration: > 10000 nM
Compound 4: a limit, no number; the forecaster's own chance of this, stated with the estimate: 20%; at least 40-fold (1.60 log units) between middle value and limit.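

Held against the earlier compounds, this result gives the first step in the set that changes one place only, on a carbonyl carbon whose other neighbour is an amide-type nitrogen. With the benzylamide and phenylsulfonyl portion kept, replacing one fused group of 9 heavy atoms with another gives, in this assay, an at least 710-fold higher number from compound 2 to compound 4 (2.85 log units; beyond the scatter), so this place tolerates far less than the shared heavy-atom count and the shared pairing of a five-membered with a six-membered aromatic ring might suggest: a fused bicyclic partner alone does not carry the potency of compound 2. Compound 4 reaches only a limit of the assay, so the step is a lower bound and the size of the loss stays unknown, and the set now reads as follows: the limit of > 10000 nM in this assay, at which 3 of the 4 values shown sit.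

The compounds shown leave open whether the sulfur that leaves or the nitrogens that enter account for the change, since both alter together in this one step. They also leave open how the group on the carbonyl carbon in compound 2 would respond to a small substituent such as an amine or a methyl group.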